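Carboxyphenyl ether variation in a modulator series

The source may report more compounds than this note shows. Statements on the series, on what has been measured and on what is new or still open speak of the compounds shown alone.

Compound 3 `Cc1c(OC[C@@H](C)COc2ccc(C(=O)O)cc2F)ccc(C(=O)CC(C)(C)C)c1O` gives 1300 nM in an assay for positive allosteric modulation of metabotropic glutamate receptor 3 (Rattus norvegicus) (a lower number here means that less compound is needed, a higher number that more compound is needed for the effect), the lowest of the two numbers in the set. Compound 1 `Cc1c(OC[C@@H](C)COc2cc(C(=O)O)ccc2F)ccc(C(=O)CC(C)(C)C)c1O` gives 3950 nM in this assay, and the step of a 3.0-fold lower number from compound 1 to compound 3 (0.48 log units; beyond the scatter) lies beyond the scatter. Compound 2 `Cc1ccc(OC[C@H](C)COc2ccc(C(=O)CC(C)(C)C)c(O)c2C)cc1C(=O)O` reaches only a limit of this assay, > 10000 nM; this is the limit of > 10000 nM in this assay, at which 1 of the 3 values shown sits. The steps of an at least 2.5-fold higher number from compound 1 to compound 2 (0.40 log units; beyond the scatter) and an at least 7.6-fold lower number from compound 2 to compound 3 (0.88 log units; beyond the scatter) place the 3-carboxy-4-methylphenyl ether as the weakest arrangement measured so far.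

Compound 4 `Cc1cc(OC[C@H](C)COc2ccc(C(=O)CC(C)(C)C)c(O)c2C)ccc1C(=O)O` is not yet measured. The change is 4-carboxy-3-methylphenyl in place of 4-carboxy-2-fluorophenyl on an oxygen on a saturated carbon. The entering 4-carboxy-3-methylphenyl keeps the carboxy numbering of the leaving group, which in the step of a 3.0-fold lower number from compound 1 to compound 3 (0.48 log units; beyond the scatter) went with a lower number, but a methyl now replaces the fluorine, and the only methyl-bearing ether measured, compound 2, sat at the limit. Of the measured steps, none swaps fluorine for methyl with the carboxy held in place, so the expectation rests on both observations together: a modest rise in the number, short of the limit. The step from compound 3 to compound 4 is therefore expected to be a 2.3-fold higher number from compound 3 to compound 4 (0.36 log units; beyond the scatter). Compound 4 is estimated to give 3000 nM in this assay, with a range from 1000 nM to 10000 nM.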

Compound 4, half-maximal effective concentration: 1350 nM
Compound 4: middle estimate off by 2.2-fold (0.35 log units), on the high side; the measured number falls inside the stated range.
By their numbers in this assay, from the lowest: compounds 3 and 4 (each within the scatter of the next); then compound 1. At a limit, above all of these: compound 2.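

In this assay, a 1.0-fold higher number from compound 3 to compound 4 (0.02 log units; within the scatter) leaves 4-carboxy-3-methylphenyl and 4-carboxy-2-fluorophenyl on this oxygen indistinguishable, so a methyl on the ring of this ether does not by itself go with a higher number, although compound 2 alone had left that reading open. The series also shows an at least 7.4-fold lower number from compound 2 to compound 4 (0.86 log units; beyond the scatter) and a 2.9-fold lower number from compound 1 to compound 4 (0.47 log units; beyond the scatter), so the two 4-carboxy ethers, compound 3 and compound 4, now stand apart from the 3-carboxy-4-methylphenyl ether and the 5-carboxy-2-fluorophenyl ether, whichever of methyl or fluorine the 4-carboxy ring carries. The first of these two steps has only a bound, as compound 2 gives a limit and not a number: the limit of > 10000 nM in this assay, at which 1 of the 4 values shown sits.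

From the compounds shown here alone, whether a 4-carboxyphenyl ether carrying neither methyl nor fluorine, or one carrying a chlorine or a methoxy group instead, stays level with compound 3 and compound 4 remains open. Also open, going by these compounds, is whether an amide or a tetrazole can stand in for the carboxylic acid on this ring.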